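Removing the Bromo Group from a Weak Adenosine Antagonist

The source may report more compounds than this note shows. Statements on the series, on what has been measured and on what is new or still open speak of the compounds shown alone.

Of the compounds shown here, two built on a shared core have been tested in a functional assay on CHO-K1 cells for antagonist activity at adenosine receptor A2b (Homo sapiens), read by 33P incorporation, with a stated time of 20 min, in the presence of a further agent that is not named here; a lower number here means a stronger inhibitor, a higher number a weaker inhibitor. Compound 1 `COc1ccc(Nc2nc3c(Cl)ncnc3s2)cc1` carries one substituted aryl amine on that core. In this assay compound 1 gives > 10000 nM, which is a limit of the assay rather than a measured number. Compound 2 `Clc1ncnc2sc(Nc3cccc(Br)c3)nc12` carries an aryl amine that bears a bromo group. In this assay compound 2 gives > 10000 nM, again a limit and not a number. Among the compounds with values here, compound 2 therefore stands at the edge of what the assay can report, and the whole body of evidence on the numbers so far is the limit of > 10000 nM in this assay, at which 2 of the 2 values shown sit; no value shown lies anywhere else.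

Compound 3 `Clc1ncnc2sc(Nc3ccccc3)nc12` differs from compound 2 by hydrogen in place of bromo on an aromatic carbon. Within the data shown here, nothing among the measured compounds shows that taking away the bromo group gains potency, and both measured compounds already sit at the limit, so the expected step in this assay is a step that the limit leaves unreadable from compound 2 to compound 3, none beyond the scatter. The estimate for compound 3 is 20000 nM, with a range from 8000 nM to 60000 nM, and most likely the assay will again report only a limit.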

Compound 3, inhibition constant: > 10000 nM
Compound 3 gave a limit, no number (the forecaster's own chance of this, stated with the estimate: 85%); the middle value lies beyond the limit too.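

Within the data shown here, no step from compound 1 or compound 2 to compound 3 can be read, since all three compounds give a limit and not a number: the limit of > 10000 nM in this assay, at which 3 of the 3 values shown sit. The compounds shown leave open how potent each of the three really is, and whether having hydrogen, bromo or methoxy on the aromatic ring changes potency at all.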